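Hydroxy for Methoxy: Expected Cytotoxicity of Compound 4

This account rests on a few compounds, and the source may have more. Where it says the series, first, only, none or still open, it means among the compounds named here.

Measured compounds:
Compound 1, `COc1cc(-c2nn(-c3cccc(NC(=O)c4ccc(Cl)c(C(F)(F)F)c4)c3)cc2-c2ccncc2)ccc1Cl`: in a functional assay on K562 cells (Homo sapiens) for inhibition, read by sulforhodamine B assay, with a stated time of 48 h (on this read-out lower numbers stand for higher toxicity in this test and higher numbers for lower toxicity in this test), compound 1 reaches only the limit > 32500 nM.
Compound 2, `COc1cc(-c2nn(-c3cccc(NC(=O)c4cccc(C(F)(F)F)c4)c3)cc2-c2ccncc2)ccc1Cl`: in this assay compound 2 reaches only the limit > 50000 nM.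
Compound 3, `COc1cc(-c2nn(-c3cccc(NC(=O)Nc4ccc(Cl)c(C(F)(F)F)c4)c3)cc2-c2ccncc2)ccc1Cl`: in this assay compound 3 reaches only the limit > 32500 nM.

Compound 3 thus stands at a limit, not at a number, and the same holds for the other two values shown: two values sit at the limit of > 32500 nM in this assay, at which 2 of the 3 values shown sit, and one at the limit of > 50000 nM in this assay, at which 1 of the 3 values shown sits. The three steps among them, a step that the two limits leave unreadable from compound 1 to compound 2, a step that the two limits leave unreadable from compound 1 to compound 3 and a step that the two limits leave unreadable from compound 2 to compound 3, are therefore unreadable in size and direction.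

Compound 4, `O=C(Nc1cccc(-n2cc(-c3ccncc3)c(-c3ccc(Cl)c(O)c3)n2)c1)Nc1ccc(Cl)c(C(F)(F)F)c1`, differs from compound 3 by hydrogen in place of methyl on an oxygen on an aromatic ring. Within the data shown here, none of the measured steps touches this oxygen, so none bears on it, and they give no readable size in any case. Compound 4 is therefore expected to behave like its three relatives, with a step that the limit leaves unreadable from compound 3 to compound 4 in this assay, that is, nothing beyond the scatter. Compound 4 is estimated at 40000 nM, within 12000 nM to 120000 nM, most likely again reported only as a limit.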

Compound 4, concentration lethal to 50% of the cells: > 32500 nM
Compound 4: no number, only a limit; the forecaster's own chance of this, stated with the estimate: 70%; the middle value lies beyond the limit too.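

In this assay compound 4 gives only a limit, > 32500 nM. Compound 3 also stands at a limit, so the step between compound 3 and compound 4 cannot be read. The compounds shown leave open whether exchanging methoxy for hydroxy changes the toxicity at all.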